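A few compounds are considered here, and "the series" means these few. Any claim that something is new, unique, unknown or untested is made for them only; others in the source may bear on it.

Measured compounds:
compound 1, `OC[C@]1(c2ccc(F)cc2)NC[C@H](O)[C@H]1O`, 8.3%;
compound 2, `OC[C@]1(c2c(F)c(F)c(F)c(F)c2F)NC[C@H](O)[C@H]1O`, 6.9%.

Both were tested in an assay on isolated protein for inhibition of lysosomal alpha-glucosidase (Homo sapiens), tested at 1000 uM; a lower number here means less inhibition, a higher number more inhibition at the concentration tested (going by the name of the read-out). In this assay compound 1 gives 8.3%, and compound 2 gives 6.9%; the two numbers lie within the usual scatter of each other, so neither compound can be placed ahead of the other, and both show little inhibition at the concentration used.

Compound 3, `OC[C@@]1(c2c(F)c(F)c(F)c(F)c2F)NC[C@@H](O)[C@@H]1O`, has not yet been measured in this assay. Compared with compound 2, (the two compounds have the same atoms and bonds and differ only in configuration as drawn: 3 of 3 stereo elements differ (all stereocentres are inverted: mirror images); a stereocentre at a saturated ring carbon is drawn S in compound 2 and R in compound 3; a stereocentre at a saturated ring carbon is drawn S in compound 2 and R in compound 3; a stereocentre at a saturated ring carbon is drawn S in compound 2 and R in compound 3). For the measured compounds named here, no measured pair in this set shows what a complete inversion of configuration does, so there is no observed step to lean on. With compound 2 giving 6.9%, the expected step from compound 2 to compound 3 is a number 8.1 percentage points higher from compound 2 to compound 3 (within the scatter), and it is uncertain whether it lies beyond the scatter. The estimated value for compound 3 in this assay is 15%, within a range from 0% to 55%.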

Compound 3, a percentage reported as inhibition, at one concentration (the size of the read-out at that concentration, not a potency): 18.5%
The estimate for compound 3 lay 3.5 percentage points below the measured number, and the stated range covers the measured number.
By their numbers in this assay, from the lowest: compounds 2 and 1 (each within the scatter of the next); then compound 3.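

Full inversion of the three stereocentres yields a number 11.6 percentage points higher from compound 2 to compound 3 (beyond the scatter) in this assay, the one difference in this set that stands clear of the scatter. The change can be assigned to configuration alone, because no atom or bond separates the two compounds: the fact that compounds 2 and 3 differ only in the configuration as drawn. Even so, compound 3 gives 18.5% in this assay, a read-out at one concentration rather than a potency, and the inhibition remains modest.

The compounds shown leave open which of the three stereocentres carries the difference, and whether the same inversion would raise the number with the aryl group of compound 1. They also leave open how the mirror-image core would respond if an amine or a carboxylic acid took the place of the hydroxymethyl group.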